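Extending a hydrazone from two triazole thioethers

The source may report more compounds than this note shows. Statements on the series, on what has been measured and on what is new or still open speak of the compounds shown alone.

The two measured compounds share a core carrying a pyridinyl group and a phenyl group, with a thioether sulfur linking to a side chain. Compound 1 `Brc1ccc(CSc2nnc(-c3ccncc3)n2-c2ccccc2)cc1` carries a 4-bromobenzyl on that sulfur, and in a functional assay on HepG2 cells (Homo sapiens) for inhibition, read by MTT assay, with a stated time of 48 h (a lower number here means a stronger inhibitor, a higher number a weaker inhibitor), compound 1 gives 12900 nM. Compound 2 `O=C(CSc1nnc(-c2ccncc2)n1-c1ccccc1)N/N=C/c1ccc(F)cc1` instead carries an acetohydrazide ending in a 4-fluorophenyl hydrazone, and in this assay compound 2 gives 9330 nM. Compound 2 holds the lower of the two numbers, yet its gap to compound 1 lies within the scatter, so neither stands apart from the other.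

Compound 3 `O=C(CSc1nnc(-c2ccncc2)n1-c1ccccc1)N/N=C/C=C/c1ccccc1` changes the hydrazone end: 2-phenylethenyl in place of 4-fluorophenyl on a carbon with a double bond to nitrogen. Among the compounds with values here, with no earlier step of this kind to lean on, only a small movement is expected. The step of a 1.2-fold lower number from compound 2 to compound 3 (0.07 log units; within the scatter) is expected to stay within the scatter. Compound 3 is therefore estimated at 8000 nM, with a range from 3000 nM to 25000 nM.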

Compound 3, half-maximal inhibitory concentration: 8280 nM
Compound 3: middle estimate off by 1.0-fold (0.01 log units), on the low side; the range from low to high includes it.
By their numbers in this assay, from the lowest: compounds 3, 2 and 1 (each within the scatter of the next).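

Within the data shown here, on a carbon with a double bond to nitrogen, 2-phenylethenyl in place of 4-fluorophenyl gives a 1.1-fold lower number from compound 2 to compound 3 (0.05 log units; within the scatter) in this assay and thus provides the first single-place step, which the two earlier compounds, differing in the whole side chain on the sulfur, could not provide. At this position, losing the fluorine and gaining a double bond outside aromatic rings leaves the number within the scatter, while the six-membered aromatic ring of carbon only remains in both groups. The data shown offer no measured explanation for this result.

The compounds shown leave open whether an amine or a carboxylic acid on this carbon would move the number beyond the scatter. They also leave open how 2-phenylethyl, or a longer chain ending in phenyl, would read here.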